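Fluoromethyl addition in a nitro-substituted aortic relaxant series

The source may report more compounds than this note shows. Statements on the series, on what has been measured and on what is new or still open speak of the compounds shown alone.

Compound 1: `N#CCC/N=C(\S)C1=CC(CF)(CF)Oc2ccc([N+](=O)[O-])cc21`, 72.5%
Compound 2: `CC1(CF)C=C(C(=O)NCCC#N)c2cc([N+](=O)[O-])ccc2O1`, 71%

Both were tested in a functional assay on the whole organism (aorta) with Rattus norvegicus as the target; a higher number here means a larger maximal response, a lower number a smaller maximal response. Compound 1 reaches 72.5% and compound 2 reaches 71%; compound 2 holds the lower of the two numbers, yet the gap to compound 1 lies within the scatter of repeated measurements, so no order between the two can be read from these data. Compound 3, `N#CCCNC(=O)C1=CC(CF)(CF)Oc2ccc([N+](=O)[O-])cc21`, has not yet been measured in this assay. It differs from compound 2 in a single place: fluoro in place of hydrogen on a saturated chain carbon bound to a saturated ring carbon. Within the data shown here, no measured pair shows this change on its own, so its effect on the maximal response is unknown. Because compound 2 stands at 71%, the step of a number 1 percentage points higher from compound 2 to compound 3 (within the scatter) is expected to stay within the scatter in either direction. Compound 3 is accordingly estimated at 72%, between 60% and 84%.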

Compound 3, intrinsic activity: the largest response reached, in percent of the reference agonist's: 72.3%
For compound 3 the middle estimate is 0.3 percentage points below the measured one, and the stated range covers the measured number.
By their numbers in this assay, from the lowest: compounds 2, 3 and 1 (each within the scatter of the next).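

In this assay, methyl to fluoromethyl, on a saturated chain carbon bound to a saturated ring carbon, now has a reading on its own: a number 1.3 percentage points higher from compound 2 to compound 3 (within the scatter) shows no separation between the two groups at this position. The exchange of the sulfur-containing group for the oxygen-containing group of the same heavy-atom count, on a double-bonded ring carbon, also gives no separation, with a number 0.2 percentage points lower from compound 1 to compound 3 (within the scatter) in the same assay. No supporting data accompany these readings.

Going by these compounds, whether trifluoromethyl or a longer chain such as ethyl at this position would separate from fluoromethyl remains open. All three compounds carry the nitro group and the nitrile, so the maximal response with an amine in place of the nitro group, or a carboxylic acid in place of the nitrile, is also unknown.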